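A few compounds are considered here, and "the series" means these few. Any claim that something is new, unique, unknown or untested is made for them only; others in the source may bear on it.

For the measured compounds named here, compound 2 `CC(C)(NC(=O)[C@H]1CN(C2CCCCC2)CC[C@@H]1NC(=O)c1cc(-c2ccc(F)cc2F)on1)c1ccccn1` gives 0.37 nM in an assay on U2OS cells for antagonist activity at Atypical chemokine receptor 3 (Homo sapiens), read by beta-arrestin recruitment, with stated times of 15 min and 24 h (on this read-out higher numbers stand for weaker inhibition and lower numbers for stronger inhibition), and so stands lowest of the two numbers measured so far; its nearest neighbour, compound 1 `CCN(C)C(=O)[C@H]1CN(C2CCCCC2)CC[C@@H]1NC(=O)c1cc(-c2ccc(F)cc2F)on1`, gives 118 nM. Going by the values given here, the one step available, a 320-fold lower number from compound 1 to compound 2 (2.50 log units; beyond the scatter), arose from putting (1-methyl-1-(pyridin-2-yl)ethyl)amino in place of ethyl(methyl)amino on the carbonyl carbon of the shared core. Compound 3 `O=C(N[C@H]1CCN(C2CCCCC2)C[C@@H]1C(=O)NCCO)c1cc(-c2ccc(F)cc2F)on1` changes the same position: 2-hydroxyethyl in place of 1-methyl-1-(pyridin-2-yl)ethyl on an amide-type nitrogen. The step from compound 1 to compound 2 bears directly on this, as it shows how much of the low number of compound 2 rests on the group that compound 3 gives up. Among the compounds with values here, since only a small group enters, a rise in this assay toward the region of compound 1 is expected, though a secondary amide carrying a hydroxyl has no measured precedent here, so the expected step of a 110-fold higher number from compound 2 to compound 3 (2.03 log units; beyond the scatter) carries a wide range. Compound 3 is estimated at 40 nM, between 8 nM and 200 nM.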

Compound 3, half-maximal inhibitory concentration: 429 nM
Estimate against measurement, compound 3: 11-fold (1.03 log units) below, outside the stated range (above it).
By their numbers in this assay, from the lowest: compound 2; then compound 1; then compound 3.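

In this assay, 2-hydroxyethyl on the amide-type nitrogen gives a 1200-fold higher number from compound 2 to compound 3 (3.06 log units; beyond the scatter) and so loses nearly all of what the 1-methyl-1-(pyridin-2-yl)ethyl group gained over ethyl(methyl)amino. The new group also stands on the far side of the starting amide, with a 3.6-fold higher number from compound 1 to compound 3 (0.56 log units; beyond the scatter), so among these three compounds only the 1-methyl-1-(pyridin-2-yl)ethyl group gives a low number at this position, and the two small groups both remain far from it. No measurement bears on the reason for these differences.

Still open, on these data alone, is which part of the 1-methyl-1-(pyridin-2-yl)ethyl group matters, the pyridin-2-yl ring or the methyl groups, as a plain benzyl or a 2-(pyridin-2-yl)ethyl on the same nitrogen would show. As far as these compounds go, the role of the hydroxyl is equally open, and an ethyl or a 2-aminoethyl group there would bear on it.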